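A few compounds are considered here, and "the series" means these few. Any claim that something is new, unique, unknown or untested is made for them only; others in the source may bear on it.

Three compounds built on the same core bear on this question. In a functional assay on LNCaP cells (Homo sapiens) for cytotoxicity, read by MTT assay, with a stated time of 72 h (a lower number here means a stronger inhibitor, a higher number a weaker inhibitor), compound 1 (`NCCCNc1c(C(=O)NCc2ccc(F)cc2)nc(Br)c2cccnc12`) has the entry "not determined" (no result reported), so it offers no number for comparison. Compound 2 (`CN(C)CCCNc1c(C(=O)NCc2ccc(F)cc2)nc(Br)c2cccnc12`) gives 8000 nM, and compound 3 (`CNCCCNc1c(C(=O)NCc2ccc(F)cc2)nc(Br)c2cccnc12`) gives 8000 nM, which leaves compound 3 level with compound 2 at the digits reported.

The next compound, compound 4 (`NCCCCCCNc1c(C(=O)NCc2ccc(F)cc2)nc(Br)c2cccnc12`), has not yet been measured. It carries 3-aminopropyl in place of methylamino on a saturated chain carbon, three bonds along the chain from a nitrogen on an aromatic ring. Read one bond further out, 3-(methylamino)propyl gives way to 6-aminohexyl.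

Going by the values given here, only one measured step is available, no change at the digits printed from compound 2 to compound 3 (within the scatter), and it replaces methyl with hydrogen on an amine nitrogen. Among the compounds with values here, that step stayed within the scatter, but it says nothing direct about a longer chain, since no measured pair changes chain length. The data therefore give no ground for expecting a shift in either direction beyond the scatter in this assay, and the uncertainty remains wide. The expected change is a 1.3-fold lower number from compound 3 to compound 4 (0.12 log units; within the scatter), an estimate that stays small. For compound 4, the estimated value is 6000 nM, with an expected range from 2500 nM to 14000 nM.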

Compound 4, half-maximal inhibitory concentration: 8000 nM
Compound 4: middle estimate off by 1.3-fold (0.12 log units), on the low side; low and high end bracket the measured number.
By their numbers in this assay, from the lowest: compounds 2, 3 and 4 (each within the scatter of the next).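

In this assay, putting 3-aminopropyl in place of methylamino on a saturated chain carbon, three bonds along the chain from a nitrogen on an aromatic ring, brought no change at the digits printed from compound 3 to compound 4 (within the scatter), and putting 3-aminopropyl in place of dimethylamino at the same place brought no change at the digits printed from compound 2 to compound 4 (within the scatter). The earlier step touched only the substituent on an amine nitrogen, whereas these two steps also change the chain itself, read one bond further out as 3-(methylamino)propyl giving way to 6-aminohexyl, and at this place and in these compounds that larger change stays within the scatter. Nothing given here accounts for why the values stay level.

The compounds shown leave open whether a chain longer than 6-aminohexyl, or a hydroxyl or a carboxylic acid in place of the amine of that chain, would move the number beyond the scatter. They also leave open whether a ring amine such as piperidine at this place would do so, since every group compared here is an open-chain amine.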